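Fluoro scan on the pyrrolidine acid diaryl ether series

The source may hold more compounds than are shown below. What is called first, only, known or untested is meant among the compounds shown, and "the series" means these compounds.

Measured compounds:
compound 1, `Cc1ccccc1Oc1ccc(N2CCC[C@H]2CC(=O)O)cc1`, 4400 nM
compound 2, `O=C(O)C[C@@H]1CCCN1c1ccc(Oc2ccccc2)cc1`, 6500 nM

Both compounds were run in an assay on HEK293 cells for binding affinity to Free fatty acid receptor 1 (Homo sapiens), read by scintillation counting and radioligand binding, with a stated time of 1 h; on this read-out lower numbers stand for stronger inhibition and higher numbers for weaker inhibition. Compound 1 gives 4400 nM in this assay; compound 2 gives 6500 nM. Among the compounds with values here, compound 2 therefore carries the highest of the two numbers, but its nearest neighbour is compound 1, and the only measured step, a 1.5-fold higher number from compound 1 to compound 2 (0.17 log units; within the scatter), is within the scatter, so the two cannot be ordered against each other.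

The next compound, compound 3, `O=C(O)C[C@@H]1CCCN1c1ccc(Oc2ccccc2F)cc1`, is not yet measured. It differs from compound 2 in one place: fluoro in place of hydrogen on an aromatic carbon.

Within the data shown here, the single measured step in this assay concerns a methyl on the aromatic carbon and says nothing about a fluoro at this place. Among the measured compounds shown here, no step bearing on a fluoro for hydrogen exchange exists, so there is no basis for expecting a shift beyond the scatter in either direction. Compound 3 is therefore estimated to sit close to compound 2 in this assay, with the expected step of a 1.3-fold lower number from compound 2 to compound 3 (0.11 log units; within the scatter). The estimate for compound 3 is 5000 nM, within a range of 1500 nM to 15000 nM.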

Compound 3, inhibition constant: 1300 nM
Compound 3: middle estimate off by 3.8-fold (0.59 log units), on the high side; measured number outside the range, below it.
By their numbers in this assay, from the lowest: compound 3; then compounds 1 and 2 (each within the scatter of the next).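

In this assay, methyl and hydrogen on this aromatic carbon, ortho to a large group, could not be told apart (a 1.5-fold higher number from compound 1 to compound 2 (0.17 log units; within the scatter)), so the position gave no sign of responding to a change. Fluoro separates from hydrogen at the same carbon, with a 5.0-fold lower number from compound 2 to compound 3 (0.70 log units; beyond the scatter), and also from methyl, with a 3.4-fold lower number from compound 1 to compound 3 (0.53 log units; beyond the scatter), so among these three compounds the position does respond, and the shift goes with fluoro rather than with any replacement of hydrogen. Both steps are modest, and nothing available accounts for fluoro behaving differently from methyl here.

Going by these compounds, it remains open whether chloro, methoxy or nitrile on this same carbon would follow fluoro or stay with methyl and hydrogen, which would show how specific the shift is to fluoro. Also open, on these data alone, is whether fluoro on the other carbons of this ring, or a second fluoro added to the 2-fluorophenyl group of compound 3, would shift the number further or leave it unchanged.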